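From Phenethyl to 4-Bromophenyl: Expecting Compound 3

The source may hold more compounds than are shown below. What is called first, only, known or untested is meant among the compounds shown, and "the series" means these compounds.

Compound 1 `O=c1cc(Cn2cc(CCCO)nn2)c2ccc(O)cc2o1`: > 100000 nM
Compound 2 `O=c1cc(Cn2cc(CCc3ccccc3)nn2)c2ccc(O)cc2o1`: 50500 nM

In a functional assay on HepG2 cells (Homo sapiens) for inhibition, read by MTT assay, with a stated time of 72 h (a lower number here means a stronger inhibitor, a higher number a weaker inhibitor), compound 1 reaches only a limit, > 100000 nM, which is the limit of > 100000 nM in this assay, at which 1 of the 2 values shown sits. Compound 2 gives 50500 nM, the one number shown, so it is the only fixed point. Going by the values given here, the single measured step is an at least 1.9-fold lower number from compound 1 to compound 2 (0.29 log units; that floor lies within the scatter). Compound 3 `O=c1cc(Cn2cc(-c3ccc(Br)cc3)nn2)c2ccc(O)cc2o1` carries 4-bromophenyl in place of phenethyl on an aromatic carbon. That earlier step touched a different position, so it bears on this change only loosely and was itself within the scatter. Compound 3 is therefore expected to move a 1.4-fold lower number from compound 2 to compound 3 (0.16 log units; within the scatter), within the scatter. Compound 3 is estimated at 35000 nM, ranging from 8000 nM to 150000 nM.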

Compound 3, half-maximal inhibitory concentration: 61100 nM
Beside the measured number, compound 3's estimate is 1.7-fold (0.24 log units) below it; measured number inside the range.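

In this assay, 4-bromophenyl in place of phenethyl on this aromatic carbon gives a 1.2-fold higher number from compound 2 to compound 3 (0.08 log units; within the scatter), so the two groups cannot be told apart here, although the position itself is now shown to accept a change. Set against 3-hydroxypropyl at the same carbon, the change gives an at least 1.6-fold lower number from compound 1 to compound 3 (0.21 log units; that floor lies within the scatter). Compound 1 stands at a limit of the assay: the limit of > 100000 nM in this assay, at which 1 of the 3 values shown sits.

The compounds shown leave open whether an amine or a carboxylic acid on this aromatic carbon would move the number beyond the scatter. They also leave open what a 4-chlorophenyl or an unsubstituted phenyl would give here.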